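Aryl-to-methyl swap on the shared core

The source may report more compounds than this note shows. Statements on the series, on what has been measured and on what is new or still open speak of the compounds shown alone.

Two measured compounds share the core of compound 2 `Cc1nc2c3ccccc3ccc2c2nc3c(ccc4ccccc43)c(-c3ccc(O)cc3)c12` and compound 1 `Cc1nc2c3ccccc3ccc2c2nc3c(ccc4ccccc43)c(-c3cc([N+](=O)[O-])ccc3N)c12`. In a functional assay, with a stated time of 90 s (on this read-out higher numbers stand for weaker inhibition and lower numbers for stronger inhibition), compound 2 gives 99 ug/mL and compound 1 gives 110 ug/mL; the pair sit within the scatter of each other, as a 1.1-fold lower number from compound 1 to compound 2 (0.05 log units; within the scatter) shows. Compound 3 `Cc1nc2c3ccccc3ccc2c2nc3c(ccc4ccccc43)c(C)c12` differs from compound 2 by methyl in place of 4-hydroxyphenyl on an aromatic carbon. For the measured compounds named here, only the step from compound 1 to compound 2 bears on it, and it exchanged one aryl for another without leaving the scatter; no measured step removes the aryl. Compound 3 is therefore expected to show no step beyond the scatter, a 1.1-fold higher number from compound 2 to compound 3 (0.05 log units; within the scatter), and its estimate is 110 ug/mL, ranging from 45 ug/mL to 270 ug/mL.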

Compound 3, half-maximal inhibitory concentration: 195 ug/mL
Beside the measured number, compound 3's estimate is 1.8-fold (0.25 log units) below it; measured number inside the range.
By their numbers in this assay, from the lowest: compounds 2, 1 and 3 (each within the scatter of the next).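

In this assay, methyl in place of 4-hydroxyphenyl gives a 2.0-fold higher number from compound 2 to compound 3 (0.29 log units; within the scatter) and methyl in place of 2-amino-5-nitrophenyl gives a 1.8-fold higher number from compound 1 to compound 3 (0.25 log units; within the scatter) on the same aromatic carbon, opposite the ring nitrogen. This position therefore now has steps that remove the aryl altogether, not only exchange it, and neither step leaves the scatter. No supporting data bear on this result.

On these data alone, whether an amine, a carboxylic acid or a longer alkyl chain here would give a step beyond the scatter stays open. So does the effect of unsubstituted phenyl on this core.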